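Bromo for hydrogen on an aromatic carbon: compound 4

The source may hold more compounds than are shown below. What is called first, only, known or untested is meant among the compounds shown, and "the series" means these compounds.

Measured so far in an assay on isolated protein for inhibition of sodium-dependent dopamine transporter (Homo sapiens), tested at 10 uM; on this read-out lower numbers stand for less inhibition and higher numbers for more inhibition at the one concentration tested (going by the name of the read-out):
compound 1, `CO[C@@H]1CN(CC2Cc3ccccc3C2)CC[C@H]1n1c(C)nc2cc(C)ccc21`, gives 8%
compound 2, `CO[C@@H]1CN(C[C@@H]2Cc3ccc(NC(=O)C(C)C)cc3C2)CC[C@H]1n1c(C)nc2cc(C)ccc21`, gives 10%
compound 3, `CO[C@@H]1CN(C[C@H]2Cc3ccc(C#N)cc3C2)CC[C@H]1n1c(C(C)(C)O)nc2cc(C)ccc21`, gives -6%

Compound 1 stands second highest of the three numbers. Its nearest neighbour is compound 2, which lies within the scatter of it; the furthest is compound 3, which lies beyond the scatter, but compound 3 differs from compound 1 in more than one place, so only the two values themselves can be set side by side.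

Compound 4, `CO[C@@H]1CN(C[C@H]2Cc3ccc(Br)cc3C2)CC[C@H]1n1c(C)nc2cc(C)ccc21`, differs from compound 1 in one place: bromo in place of hydrogen on an aromatic carbon. Going by the values given here, the change sits on an aromatic carbon of a six-membered aromatic ring of carbon only, part of a fused or bridged system of two rings, the same ring that carries the change of the one measured single step. That step, a number 2 percentage points higher from compound 1 to compound 2 (within the scatter), put a larger group onto this ring without moving the read-out beyond the scatter. Nothing in the data speaks for a larger move from a bromo group here.

The expected step, no change at the digits printed from compound 1 to compound 4 (within the scatter), is therefore none beyond the scatter. Compound 4 is expected to give 8% in this assay, with a range from -5% to 21%.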

Compound 4, a percentage reported as inhibition, at one concentration (the size of the read-out at that concentration, not a potency): 80%
Compound 4: the middle estimate sits 72 percentage points below what was measured; the whole stated range lies below it.
By their numbers in this assay, from the lowest: compound 3; then compounds 1 and 2 (each within the scatter of the next); then compound 4.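

In this assay, this aromatic carbon is not indifferent to substitution: bromo in place of hydrogen gives a number 72 percentage points higher from compound 1 to compound 4 (beyond the scatter), a change of one heavy atom that adds no ring, no hydrogen-bond donor or acceptor and no net charge. On the same ring, (isopropylcarbonyl)amino gives a number 2 percentage points higher from compound 1 to compound 2 (within the scatter), so across these two groups the outcome depends on which group enters, not simply on whether the ring carries a group. The data at hand offer no explanation for why bromo and (isopropylcarbonyl)amino part so sharply on this ring.

As far as these compounds go, whether chloro, iodo or a methyl group at this carbon would give a number near that of compound 4 remains open, so it cannot yet be said whether the step is particular to bromo or shared by other small groups. Also open, from the compounds shown here alone, are whether bromo gives a comparable step on the core of compound 3, and what potency lies behind a percentage read at a single concentration.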